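Swapping the urea amine on a shared core

The source may hold more compounds than are shown below. What is called first, only, known or untested is meant among the compounds shown, and "the series" means these compounds.

Compound 1 `CCN(C)C(=O)N1CCN(C(=S)SCc2cn(Cc3ccccc3F)nn2)CC1` and compound 2 `Cc1ccc(Cn2cc(CSC(=S)N3CCN(C(=O)NC(C)C)CC3)nn2)cc1` share one core and differ in two places at once: the group on the urea carbonyl and the substituent on the benzyl ring. In a functional assay on EC9706 cells (Homo sapiens) for cytotoxicity, read by MTT assay, with a stated time of 72 h (on this read-out lower numbers stand for stronger inhibition and higher numbers for weaker inhibition), compound 1 gives 15600 nM. For compound 2 only a limit is known: compound 2 sits at the limit of > 128000 nM in this assay, at which 1 of the 2 values shown sits, and that limit, > 128000 nM, is a boundary of the assay rather than a number. Compound 3 `CCN(C)C(=O)N1CCN(C(=S)SCc2cn(Cc3ccc(C)cc3)nn2)CC1` is not yet measured. It differs from compound 2 by ethyl(methyl)amino in place of isopropylamino on a carbonyl carbon. Because no single change between measured compounds is available here, the size of this step cannot be read from the numbers directly; the step from compound 2 to compound 3 is expected to move towards stronger inhibition, as an at least 2.8-fold lower number from compound 2 to compound 3 (0.45 log units; beyond the scatter), though with wide uncertainty since compound 2 itself is only a limit. That expectation leans on compound 1, which carries the same ethyl(methyl)carbamoyl group and gives 15600 nM. Compound 3 is therefore estimated at 45000 nM, within a range from 12000 nM to 128000 nM.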

Compound 3, half-maximal inhibitory concentration: 70600 nM
The estimate for compound 3 lay 1.6-fold (0.20 log units) below the measured number; the measured number falls inside the stated range.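

Compound 2 is still a limit and not a number in this assay: the limit of > 128000 nM in this assay, at which 1 of the 3 values shown sits. Read against that limit, ethyl(methyl)amino in place of isopropylamino on the carbonyl carbon gives an at least 1.8-fold lower number from compound 2 to compound 3 (0.25 log units; that floor lies within the scatter), so this change at the urea can be bounded on one side but not sized, and the data cannot say whether it matters at all. Going by these compounds alone, the clearer news comes from the other end of the molecule: with the ethyl(methyl)carbamoyl group held fixed, 4-methylphenyl in place of 2-fluorophenyl on the saturated chain carbon bound to an aromatic nitrogen gives a 4.5-fold higher number from compound 1 to compound 3 (0.66 log units; beyond the scatter), the first single change here whose size can be read.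

Whether the fluorine or the methyl carries that step is open, as is where an unsubstituted phenyl or a 4-chlorophenyl would fall relative to compound 1 and compound 3. As far as these compounds go, on the urea side, it also remains open how a dimethylamino or a diethylamino group on the same carbonyl carbon would read on this shared core.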